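Carbonate ester variants on a shared core: stability outlook

A few compounds are considered here, and "the series" means these few. Any claim that something is new, unique, unknown or untested is made for them only; others in the source may bear on it.

Measured compounds:
compound 1 `CC(C)C(=O)OCOC(=O)N1CCN(C(=O)c2nc(Nc3cc(C4CC4)[nH]n3)c3cc(Cl)ccc3n2)C[C@H]1C` — 14%
compound 2 `CC(OC(=O)N1CCN(C(=O)c2nc(Nc3cc(C4CC4)[nH]n3)c3cc(Cl)ccc3n2)C[C@H]1C)OC(=O)C(C)(C)C` — 66.3%
compound 3 `COC(=O)N1CCN(C(=O)c2nc(Nc3cc(C4CC4)[nH]n3)c3cc(Cl)ccc3n2)C[C@H]1C` — 34.2%

In an ADME assay on S9 fraction from liver (Rattus norvegicus), read by LC-MS, with a stated time of 60 min, at 37 degrees C (on this read-out lower numbers stand for a less stable compound and higher numbers for a more stable compound), compound 3 sits second highest of the three: compound 1 lies nearer, with a number 20.2 percentage points higher from compound 1 to compound 3 (beyond the scatter), while compound 2 lies furthest, with a number 32.1 percentage points lower from compound 2 to compound 3 (beyond the scatter). Compound 4 `CC(OC(=O)C(C)C)OC(=O)N1CCN(C(=O)c2nc(Nc3cc(C4CC4)[nH]n3)c3cc(Cl)ccc3n2)C[C@H]1C` carries 1-((isopropylcarbonyl)oxy)ethyl in place of methyl on an oxygen next to a carbonyl group. Among the measured compounds shown here, two measured steps bear on it: a number 32.1 percentage points lower from compound 2 to compound 3 (beyond the scatter) and a number 20.2 percentage points higher from compound 1 to compound 3 (beyond the scatter), which pull in opposite directions, since compound 4 shares its ethyl branch with compound 2 but its isopropyl group with compound 1. The expected step is therefore small and uncertain, a number 1.8 percentage points higher from compound 3 to compound 4 (within the scatter), with a wide range. Compound 4 is estimated at 36%, between 12% and 64%.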

Compound 4, percent of the compound remaining: 11%
Compound 4: middle estimate off by 25 percentage points, on the high side; measured number outside the range, below it.
By their numbers in this assay, from the lowest: compounds 4 and 1 (each within the scatter of the next); then compound 3; then compound 2.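

In this assay, 1-((isopropylcarbonyl)oxy)ethyl in place of methyl on the oxygen gives a number 23.2 percentage points lower from compound 3 to compound 4 (beyond the scatter) and so does not match the higher number of compound 2. Methyl in place of hydrogen on the chain carbon bound to two oxygens gives a number 3 percentage points lower from compound 1 to compound 4 (within the scatter), whereas methyl in place of hydrogen on the carbon bound to a carbonyl carbon and two saturated chain carbons, read in the reverse direction, corresponds to a number 55.3 percentage points lower from compound 2 to compound 4 (beyond the scatter). Among these compounds, the high number therefore goes with the tert-butyl end, not the ethyl branch alone. No evidence on the cause is available. As far as these compounds go, whether tert-butyl holds the number without the ethyl branch stays open, as does the outcome with an amine or a carboxylic acid at the chain end.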